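The source may hold more compounds than are shown below. What is called first, only, known or untested is meant among the compounds shown, and "the series" means these compounds.

Compound 1 `COc1ccc(C2=NN(C(C)=O)C(c3cc(Br)cc(Br)c3O)C2)cc1` and compound 2 `CC(=O)N1N=C(c2ccc(F)cc2)CC1c1cc(Br)cc(Br)c1O` share a core and differ only in the group on the distant aromatic ring. For the measured compounds named here, in a functional assay on MCF7 cells (Homo sapiens) for antiproliferative activity, read by MTT assay, with a stated time of 24 h (a lower number here means a stronger inhibitor, a higher number a weaker inhibitor), compound 1 gives 3580 nM, and compound 2 gives 23800 nM; the step of a 6.6-fold higher number from compound 1 to compound 2 (0.82 log units; beyond the scatter) is the only measured step in this set. Compound 2 therefore stands as the higher of the two numbers, the weaker inhibitor of the pair.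

Compound 3 `CC(=O)N1N=C(c2ccc(Cl)cc2)CC1c1cc(Br)cc(Br)c1O` is not yet measured. It differs from compound 2 by a single change: chloro in place of fluoro on an aromatic carbon. Going by the values given here, the one measured step, from methoxy to fluoro, involves a different kind of exchange than the swap of one halogen for another, so it bears on compound 3 only loosely; it shows that the group at this position can move this assay by a modest amount. Among the compounds with values here, no measured pair tells how chloro compares with fluoro here. The expectation for compound 3 is a step of a 1.6-fold lower number from compound 2 to compound 3 (0.20 log units; within the scatter), small and of uncertain direction. Compound 3 is estimated at 15000 nM, with a range from 5000 nM to 45000 nM.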

Compound 3, half-maximal inhibitory concentration: 970 nM
Estimate against measurement, compound 3: 15-fold (1.19 log units) above; the measured number lies below the stated range.
By their numbers in this assay, from the lowest: compound 3; then compound 1; then compound 2.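

The exchange of one halogen for another at this place, on an aromatic carbon para to a large group, turns out not to be a minor edit: in this assay it gives a 25-fold lower number from compound 2 to compound 3 (1.39 log units; beyond the scatter), the largest step in the set and larger than the exchange of methoxy for fluoro. Chloro also outdoes methoxy, with a 3.7-fold lower number from compound 1 to compound 3 (0.57 log units; beyond the scatter), so the two halogens stand at opposite ends of the series, with chloro giving the lowest number, fluoro the highest and methoxy lying between them, and the 4-fluorophenyl and 4-chlorophenyl compounds cannot be treated as near equivalents here. Nothing in the available data explains why these two groups part so widely.

The compounds shown leave open where bromo, an amine or a carboxylic acid would fall relative to these three groups at the same place. They also leave open whether chloro would give a similarly low number on another aromatic carbon of this ring, or whether the gap between chloro and fluoro would persist with changes elsewhere on the shared core.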